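A Ring Gives Way to an Octyl Chain

A few compounds are considered here, and "the series" means these few. Any claim that something is new, unique, unknown or untested is made for them only; others in the source may bear on it.

Measured in a physicochemical assay for solubility, at pH 7.4; on this read-out higher numbers stand for higher solubility and lower numbers for lower solubility:
- compound 1 `CC1(c2nc(-c3ccc(CNC(=O)[C@H]4NCC[C@@H]4O)cc3)no2)CCCCC1` gives > 50 ug/mL as a limit
- compound 2 `CCCCCCCc1nc(-c2ccc([C@@H](C)NC(=O)[C@H]3NCC[C@@H]3O)cc2)no1` gives 27 ug/mL
- compound 3 `CCCCCCCc1nnc(-c2ccc(CNC(=O)[C@H]3NCC[C@@H]3O)cc2)o1` gives 2.1 ug/mL

Compound 1 stands at a limit and not at a number: the limit of > 50 ug/mL in this assay, at which 1 of the 3 values shown sits. Compound 4 `CCCCCCCCc1nc(-c2ccc(CNC(=O)[C@H]3NCC[C@@H]3O)cc2)no1` keeps the core of compound 1 but carries octyl in place of 1-methylcyclohexyl on an aromatic carbon. Among the measured compounds shown here, no measured pair differs in only one place, so the size of this step in this assay can only be judged loosely. Compound 2 reads 27 ug/mL and compound 3 reads 2.1 ug/mL in this assay, and each has an open chain with no ring in that place, although they also differ elsewhere. On that thin basis, a fall beyond the usual scatter is expected. The estimate means an expected fall an at least 5.0-fold lower number from compound 1 to compound 4 (0.69 log units; beyond the scatter) in this measurement. For compound 4 the estimated solubility is 10 ug/mL, with an expected range from 2 ug/mL to 40 ug/mL in this assay.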

Compound 4, solubility: 4 ug/mL
Beside the measured number, compound 4's estimate is 2.5-fold (0.40 log units) above it; the measured number falls inside the stated range.
By their numbers in this assay, from the lowest: compounds 3 and 4 (each within the scatter of the next); then compound 2. At a limit, above all of these: compound 1.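

This is the only pair shown that differs in a single place, so swapping 1-methylcyclohexyl for octyl on the aromatic carbon can now be read directly, not inferred from compounds that also differ elsewhere. In this assay the change gives an at least 12-fold lower number from compound 1 to compound 4 (1.09 log units; beyond the scatter), a large step, even though neither group carries hydrogen-bond donors, hydrogen-bond acceptors or a net charge. Compound 1 stands at a limit, so the step is a minimum and its full size cannot be read: the limit of > 50 ug/mL in this assay, at which 1 of the 4 values shown sits.

Because the ring is lost as the chain's size changes, the compounds shown cannot separate the two. Also open, as far as these compounds go, is how a shorter chain such as hexyl, or an octyl chain ending in an amine, would read at this position.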